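A few compounds are considered here, and "the series" means these few. Any claim that something is new, unique, unknown or untested is made for them only; others in the source may bear on it.

Two close relatives share one core and differ only in the ring on a saturated chain carbon bound to an aromatic nitrogen. In an in vitro ADME assay on microsomes from liver (Rattus norvegicus) for metabolic stability (a lower number here means slower removal, a higher number faster removal of the compound), compound 1 `Cc1ccc(Cn2c(=O)[nH]c3c(N)nc(C(F)(F)F)cc32)cn1` gives < 8.5 mL.min-1.g-1. That value is a limit of the assay and not a number. Within the data shown here, compound 2 `Cc1cccc(Cn2c(=O)[nH]c3c(N)nc(C(F)(F)F)cc32)n1` gives 27 mL.min-1.g-1, the only true number so far in this assay. Having 6-methylpyridin-2-yl in place of 6-methylpyridin-3-yl gave an at least 3.1-fold higher number from compound 1 to compound 2 (0.50 log units; beyond the scatter), so the ring at this place can move the read-out beyond the scatter.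

Compound 3 `Cc1nc(Cn2c(=O)[nH]c3c(N)nc(C(F)(F)F)cc32)cs1` carries 2-methyl-1,3-thiazol-4-yl in place of 6-methylpyridin-2-yl (2-methyl-1,3-thiazol-4-yl in place of 6-methylpyridin-2-yl on a saturated chain carbon bound to an aromatic nitrogen). Among the measured compounds shown here, that single measured step bears on this change only loosely, and no compound with a five-membered aromatic ring has been measured yet. Compound 2, at 27 mL.min-1.g-1, already sits on the high side of that step, so a new ring seems more likely to lower the number than to raise it. The expected change is small, a 1.7-fold lower number from compound 2 to compound 3 (0.23 log units; within the scatter), and it may not clear the scatter. For compound 3 the estimated value is 16 mL.min-1.g-1, with an expected range of 8.5 mL.min-1.g-1 to 40 mL.min-1.g-1.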

Compound 3, intrinsic clearance in microsomes: < 10 mL.min-1.g-1
Compound 3 ended at the assay's limit; the forecaster's own chance of this, stated with the estimate: 25%; middle value at least 1.6-fold (0.20 log units) from the limit.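

In this assay, putting 2-methyl-1,3-thiazol-4-yl in place of 6-methylpyridin-2-yl gave an at least 2.7-fold lower number from compound 2 to compound 3 (0.43 log units; beyond the scatter), which shows that a five-membered aromatic ring can take this place on a saturated chain carbon bound to an aromatic nitrogen and that swapping the ring here can lower the number beyond the scatter. Among these compounds, the reading for compound 3 is a limit of the assay and not a number: the limit of < 10 mL.min-1.g-1 in this assay, at which 1 of the 3 values shown sits. Together with the earlier step, this leaves compound 2 as the one compound of the three with a true number, and its 6-methylpyridin-2-yl ring differs beyond the scatter from each of the other two rings, so a change of ring at this place can matter in either direction.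

Going by these compounds, the two limits leave the step between compound 1 and compound 3 unreadable, so how the 6-methylpyridin-3-yl and 2-methyl-1,3-thiazol-4-yl rings rank against each other stays open. Also open, on these data alone, is how this assay would read at this place for a plain phenyl ring, which has no ring nitrogen and no methyl group, or for something that is not an aromatic ring at all, such as a longer chain.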